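A few compounds are considered here, and "the series" means these few. Any claim that something is new, unique, unknown or untested is made for them only; others in the source may bear on it.

Measured compounds:
compound 1 `Nc1nc(O)c2c(n1)n(C1OC(CO)[C@@H](O)[C@H]1O)c(=O)n2Cc1ccc(Cl)c(Cl)c1` gives 15%
compound 2 `C=CCn1c(=O)n([C@H]2CO[C@@H](CO)C2)c2nc(N)nc(O)c21` gives 0%
compound 3 `N#Cc1cccc(Cn2c(=O)n(C3OC(CO)[C@@H](O)[C@H]3O)c3nc(N)nc(O)c32)c1` gives 11%

In a functional assay on YAC-1 cells (Mus musculus) (on this read-out lower numbers stand for smaller maximal responses and higher numbers for larger maximal responses), compound 3 sits within the scatter of compound 1 and clearly above compound 2, whose value is beyond the scatter. Compound 4 `Cn1c(=O)n(C2OC(CO)[C@@H](O)[C@H]2O)c2nc(N)nc(O)c21` differs from compound 3 by hydrogen in place of 3-cyanophenyl on a saturated chain carbon bound to an aromatic nitrogen. Among the compounds with values here, the only measured step at that place, a number 4 percentage points lower from compound 1 to compound 3 (within the scatter), exchanged one aromatic group for another and stayed within the scatter; no measured step removes the whole group. Compound 2 carries a short chain at that position together with a different sugar, and compound 2 gives 0%, the lowest number seen. A modest downward step is therefore expected, a number 6 percentage points lower from compound 3 to compound 4 (within the scatter). Compound 4 is estimated at 5%, with a range from 0% to 14%.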

Compound 4, largest response reached (reported as maximal response), in percent of the reference or control that the assay uses: 72%
Beside the measured number, compound 4's estimate is 67 percentage points below it; the whole stated range lies below it.
By their numbers in this assay, from the lowest: compound 2; then compounds 3 and 1 (each within the scatter of the next); then compound 4.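

In this assay the place on a saturated chain carbon bound to an aromatic nitrogen proves highly sensitive: hydrogen in place of the ring gives a number 61 percentage points higher from compound 3 to compound 4 (beyond the scatter) and a number 57 percentage points higher from compound 1 to compound 4 (beyond the scatter) as the same kind of change. Exchanging one aromatic group for another had not shown this, so the high number appears only once the ring is gone and a methyl remains. Nothing available bears on why this happens. On these data alone, whether ethyl, a longer chain or an amine at this place would keep the high response stays open. So does whether an unsubstituted benzyl would behave like compound 1 and compound 3.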